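Adding a 4-chlorobenzyl group to compound 2

This account rests on a few compounds, and the source may have more. Where it says the series, first, only, none or still open, it means among the compounds named here.

In a functional assay on PC-3 cells (Homo sapiens) for cytotoxicity, read by WST assay, with a stated time of 24 h (on this read-out higher numbers stand for weaker inhibition and lower numbers for stronger inhibition), compound 2 `N#C/C(=C\c1c[nH]c2ccccc12)C(=O)c1c[nH]c2ccccc12` gives > 50000 nM, which is a limit and not a number. Compound 3 `COc1ccc2c(C(=O)/C(C#N)=C/c3c[nH]c4ccccc34)c[nH]c2c1` gives > 50000 nM, again a limit. For the measured compounds named here, the one measured step is a step that the two limits leave unreadable from compound 2 to compound 3, so it offers no size to build on. Most of the data stop at the limit of > 50000 nM in this assay, at which 2 of the 3 values shown sit.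

Compound 4 `N#C/C(=C\c1cn(Cc2ccc(Cl)cc2)c2ccccc12)C(=O)c1c[nH]c2ccccc12` puts 4-chlorobenzyl in place of hydrogen on an aromatic nitrogen, and the change is 4-chlorobenzyl in place of hydrogen on an aromatic nitrogen. Going by the values given here, no measured step isolates this change. The nearest guide is compound 1 `N#C/C(=C\c1cn(Cc2ccc(Cl)cc2)c2ccc(Br)cc12)C(=O)c1c[nH]c2ccccc12`, which carries the same 4-chlorobenzyl group plus one further difference on the core and gives 47100 nM, a real number. With compound 1 at 47100 nM as the only hint, a small step toward stronger inhibition, or none beyond the scatter, is expected in this assay. The expected size is an at least 1.1-fold lower number from compound 2 to compound 4 (0.04 log units; that floor lies within the scatter). For compound 4 the estimate is 45000 nM, with an expected range from 20000 nM to 75000 nM.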

Compound 4, half-maximal inhibitory concentration: > 50000 nM
Compound 4 gave a limit, no number; the forecaster's own chance of this, stated with the estimate: 50%; middle value at least 1.1-fold (0.04 log units) away from the limit.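

In this assay compound 4 gives > 50000 nM, which is a limit and not a number, so 4-chlorobenzyl in place of hydrogen on the aromatic nitrogen does not by itself bring a readable value: the limit of > 50000 nM in this assay, at which 3 of the 4 values shown sit.

Steps that join two limits cannot be read, and this holds for compound 2 with compound 3 and with compound 4. Hydrogen in place of bromo on an aromatic carbon gives an at least 1.0-fold higher number from compound 1 to compound 4 (0.02 log units; that floor lies within the scatter), so the true step may be larger, but the data do not show that bromo matters beyond the scatter.

On these data alone, what bromo does on the core without 4-chlorobenzyl remains open. So does whether a methyl group or a chain ending in an amine on that aromatic nitrogen would give a readable value.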